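Benzyl Chloro Addition on an Aryl Propanamide Scaffold

The compounds below may be only part of what the source reports. "The series", "measured", "known", "first", "only" and "open" are said of these compounds alone.

Of the compounds shown here, three have numbers so far in a functional assay on CHO cells for antagonist activity at transient receptor potential cation channel subfamily V member 1 (Rattus norvegicus); a lower number here means a stronger inhibitor, a higher number a weaker inhibitor. Compound 1 `COc1cc(C2(C(=O)NCc3ccc(C(C)(C)C)cc3)CC2)ccc1NS(C)(=O)=O` gives 2250 nM in this assay. Compound 2 `CC(NC(=O)/C=C/c1ccc(C(C)(C)C)cc1)c1ccc(NS(C)(=O)=O)c(F)c1` gives 23.9 nM in this assay. Compound 3 `CC(C(=O)NCc1ccc(Cl)cc1)c1ccc(NS(C)(=O)=O)c(F)c1` gives 367 nM in this assay. Among these three numbers, compound 3 stands second highest: compound 1 is the nearest, with a higher number that lies beyond the scatter, and compound 2 is the furthest, with a lower number that also lies beyond the scatter. Compound 1, compound 2 and compound 3 each differ from one another in more than one place, so no single-change step can be read from the measured set.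

Compound 4 `CC(C(=O)NCc1ccc(Cl)c(Cl)c1)c1ccc(NS(C)(=O)=O)c(F)c1` has not yet been measured in this assay. It differs from compound 3 by chloro in place of hydrogen on an aromatic carbon. Within the data shown here, no measured pair shows this particular change, so the size of the step has to be estimated rather than read. A modest move towards a lower number is expected, the step of a 2.0-fold lower number from compound 3 to compound 4 (0.31 log units; beyond the scatter) reflecting a change within or close to the scatter. For compound 4 the estimated value in this assay is 180 nM, with an expected range from 60 nM to 550 nM.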

Compound 4, inhibition constant: 115 nM
Beside the measured number, compound 4's estimate is 1.6-fold (0.19 log units) above it; the range from low to high includes it.
By their numbers in this assay, from the lowest: compound 2; then compound 4; then compound 3; then compound 1.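

Among these compounds, replacing hydrogen with chloro, which turns the 4-chlorophenyl group into 3,4-dichlorophenyl, gives the first single-change step in this assay: a 3.2-fold lower number from compound 3 to compound 4 (0.50 log units; beyond the scatter). This shows that the aromatic carbon ortho to the existing chloro group and meta to the large group accepts a second chloro, with a modest gain that lies beyond the scatter and no loss of inhibition. The series offers no measurement that accounts for this gain, so the step stands as an observation only.

Whether the gain is specific to chloro remains open, as the compounds shown do not reveal what a methyl, a trifluoromethyl or a nitrile on the same carbon would give, or whether the step depends on the chloro group already present. Going by these compounds, it is also open whether the same step would appear on a benzyl group carrying tert-butyl, as in compound 1, or on the core of that compound.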